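The source may report more compounds than this note shows. Statements on the series, on what has been measured and on what is new or still open speak of the compounds shown alone.

Measured compounds: compound 1 `O=C(CCCCCCc1ccccc1)c1ncc(-c2ccc(CCl)cn2)o1` gives 22.4 nM in an assay for inhibition of Fatty-acid amide hydrolase 1 (Rattus norvegicus), using a Dixon plot; on this read-out lower numbers stand for stronger inhibition and higher numbers for weaker inhibition; compound 2 `CSCc1ccc(-c2cnc(C(=O)CCCCCCc3ccccc3)o2)nc1` gives 11.1 nM in this assay.

Compound 2 stands at the lowest of the two numbers, with compound 1 as its nearest neighbour by a 2.0-fold lower number from compound 1 to compound 2 (0.30 log units; within the scatter). The unmeasured compound 3 `O=C(CCCCCCc1ccccc1)c1ncc(CCCCCBr)o1` differs from compound 2 by a group of 6 heavy atoms (5 carbon, 1 bromine; no ring) in place of a group of 9 heavy atoms (7 carbon, 1 nitrogen, 1 sulfur; one six-membered aromatic ring with 1 hetero atom), on an aromatic carbon. For the measured compounds named here, the only measured step, a 2.0-fold lower number from compound 1 to compound 2 (0.30 log units; within the scatter), concerns an exchange within the group that now leaves entirely, so no measured step bears directly on this change; the change from compound 2 to compound 3 removes the whole six-membered aromatic ring and is far larger than anything measured. Given that absence of guidance, the estimate rests on the size of the change alone: compound 3 is expected to show a weaker number, a step of a 9.0-fold higher number from compound 2 to compound 3 (0.95 log units; beyond the scatter), with compound 3 estimated at 100 nM in a range from 20 nM to 600 nM.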

Compound 3, inhibition constant: 6.1 nM
The estimate for compound 3 lay 16-fold (1.21 log units) above the measured number; measured number below the stated range.
By their numbers in this assay, from the lowest: compounds 3, 2 and 1 (each within the scatter of the next, the first and the last beyond it).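

At this position, next to the ring oxygen, the comparison in this assay shows that the whole group carrying the six-membered aromatic ring can give way to 5-bromopentyl, which has no ring, with a 1.8-fold lower number from compound 2 to compound 3 (0.26 log units; within the scatter) marking the exchange. Measured against the chlorine-bearing group, the same chain gives a 3.7-fold lower number from compound 1 to compound 3 (0.56 log units; beyond the scatter) as a modest step, so a ring at this place is not required for a number in this range. No evidence at hand accounts for this result.

As far as these compounds go, it remains open whether the terminal bromine contributes anything, which a plain pentyl chain would test. From the compounds shown here alone, it is equally open how a shorter or longer chain would read at this place, or a chain ending in an amine or a carboxylic acid.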